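Swapping the chalcone arm on a fused two-ring core

The compounds below may be only part of what the source reports. "The series", "measured", "known", "first", "only" and "open" are said of these compounds alone.

Compound 2 `COc1cc(-c2cc(C(=O)/C=C/c3ccc(C)cc3)nc3cc(-c4ccccc4)nn23)cc(OC)c1OC`: 18600 nM
Compound 3 `COc1ccc(-c2cc(C(=O)/C=C/c3ccc(C)cc3)nc3cc(-c4ccccc4)nn23)cc1OC`: 22600 nM
Compound 1 `COc1ccc(-c2cc(/C=C/C(=O)c3ccc(OC)c(OC)c3)nc3cc(-c4ccccc4)nn23)cc1`: 8700 nM

In a functional assay on MDA-MB-231 cells (Homo sapiens) for antiproliferative activity, read by MTT assay, with a stated time of 24 h (on this read-out lower numbers stand for stronger inhibition and higher numbers for weaker inhibition), compound 2 stands second highest of three numbers. Its nearest neighbour is compound 3, with a 1.2-fold higher number from compound 2 to compound 3 (0.08 log units; within the scatter). For the measured compounds named here, compound 1 shows a lower number than compound 2 in this assay, though the two differ in several places and no single step connects them. Compound 4 `COc1ccc(C(=O)/C=C/c2cc(-c3cc(OC)c(OC)c(OC)c3)n3nc(-c4ccccc4)cc3n2)cc1` is obtained from compound 2 by 2-((4-methoxyphenyl)carbonyl)ethenyl in place of (2-(4-methylphenyl)ethenyl)carbonyl on an aromatic carbon. Going by the values given here, no measured step covers this change; the only step available, from compound 2 to compound 3, is within the scatter and concerns a different part of the molecule. The lower number of compound 1, which shares the entering arrangement of the arm, suggests a modest move toward lower numbers. The estimated step is a 1.9-fold lower number from compound 2 to compound 4 (0.27 log units; within the scatter), giving compound 4 an expected value of 10000 nM (range 4000 nM to 25000 nM).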

Compound 4, half-maximal inhibitory concentration: 13200 nM
The estimate for compound 4 lay 1.3-fold (0.12 log units) below the measured number; low and high end bracket the measured number.
By their numbers in this assay, from the lowest: compounds 1, 4, 2 and 3 (each within the scatter of the next, the first and the last beyond it).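

For the compounds shown here, the arm on this aromatic carbon can be exchanged without leaving the scatter: in this assay the change gives a 1.4-fold lower number from compound 2 to compound 4 (0.15 log units; within the scatter), whereas the only earlier step concerned a methoxy on another part of the molecule. Nothing available explains this result. On these data alone, the change alters two things at once, the place of the carbonyl within the arm and methyl for methoxy on the arm's ring, so their separate contributions stay unknown. As far as these compounds go, whether an amine or a carboxylic acid on that ring would move the number beyond the scatter also stays open.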